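Adding a hydroxy group to compound 3

The source may hold more compounds than are shown below. What is called first, only, known or untested is meant among the compounds shown, and "the series" means these compounds.

In a functional assay on HT-29 cells (Homo sapiens) for antiproliferative activity, read by MTT assay, with a stated time of 24 h (a lower number here means a stronger inhibitor, a higher number a weaker inhibitor), compound 3 `COc1ccc(C(=O)/C=C/c2ccccc2Cl)c2c1C=CC(C)(C)O2` gives > 10000 nM as its reading, and this is a limit, not a number. Compound 3 therefore sits at the limit of > 10000 nM in this assay, at which 2 of the 3 values shown sit, and cannot be placed more exactly. Compound 1 `COc1ccc(C(=O)/C=C/c2ccsc2)c2c1C=CC(C)(C)O2` gives > 10000 nM as a limit too. Compound 2 `COc1ccc(C(=O)/C=C/c2ccc(Cl)c(Cl)c2)c2c1C=CC(C)(C)O2` gives 7580 nM as a true number.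

Compound 4 `COc1ccc(C(=O)/C=C/c2cc(Cl)ccc2O)c2c1C=CC(C)(C)O2` carries a new group on a double-bonded chain carbon bound to a double-bonded chain carbon, and 5-chloro-2-hydroxyphenyl in place of 2-chlorophenyl on a double-bonded chain carbon bound to a double-bonded chain carbon is the full difference. Three measured steps changed that same place, namely an at least 1.3-fold lower number from compound 1 to compound 2 (0.12 log units; that floor lies within the scatter) along with an at least 1.3-fold higher number from compound 2 to compound 3 (0.12 log units; that floor lies within the scatter) and finally a step that the two limits leave unreadable from compound 1 to compound 3 as well. Neither floor passes the scatter and the third step has no readable size, so no step beyond the scatter is expected in this assay in either direction. The expected step is an at least 1.1-fold lower number from compound 3 to compound 4 (0.04 log units; that floor lies within the scatter) on this reasoning. Compound 4 is estimated at 9000 nM with an expected range from 3500 nM to 20000 nM in this test.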

Compound 4, half-maximal inhibitory concentration: 4970 nM
Compound 4: the middle estimate sits 1.8-fold (0.26 log units) above what was measured; low and high end bracket the measured number.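

In this assay, among the compounds shown here, the change at this place gives an at least 2.0-fold lower number from compound 3 to compound 4 (0.30 log units; that floor lies within the scatter): 5-chloro-2-hydroxyphenyl, the first group here with a hydrogen-bond donor, yields a true number where 2-chlorophenyl yielded only a limit. Set against thiophen-3-yl, the same group gives an at least 2.0-fold lower number from compound 1 to compound 4 (0.30 log units; that floor lies within the scatter), while against 3,4-dichlorophenyl it gives a 1.5-fold lower number from compound 2 to compound 4 (0.18 log units; within the scatter), so the two groups with true numbers cannot be told apart. The first two steps are floors rather than sizes, because their starting compounds carry a limit instead of a number: the limit of > 10000 nM in this assay, at which 2 of the 4 values shown sit.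

Compound 4 differs from compound 3 in both the hydroxy group and the placing of the chlorine, and the compounds shown do not separate these two changes. Also open, on these data alone, is how an amine or a carboxylic acid in place of the hydroxy group would read, and whether any group at this place can move the number beyond the scatter.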